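The source may report more compounds than this note shows. Statements on the series, on what has been measured and on what is new or still open speak of the compounds shown alone.

Compound 1 `Cc1ccc(Cn2cc(CNC(=O)c3cnc(Nc4ccc(C#N)cc4)cc3Oc3c(C)cc(C)cc3C)nn2)cc1` gives 165000 nM in an ADME assay on MT4 cells (Homo sapiens) for cytotoxicity, read by MTT assay, with a stated time of 5 days; a higher number here means that more compound is tolerated, a lower number that less compound is tolerated.
Compound 2 `Cc1cc(C)c(Oc2cc(Nc3ccc(C#N)cc3)ncc2C(=O)NCc2cn(Cc3cccc(Cl)c3)nn2)c(C)c1` gives 187000 nM in this assay.

The step of a 1.1-fold higher number from compound 1 to compound 2 (0.05 log units; within the scatter) lies within the scatter, so compound 2 and compound 1 stand level on the numbers shown. Compound 3 `Cc1cc(C)c(Oc2cc(Nc3ccc(C#N)cc3)ncc2C(=O)NCc2cn(CCC#N)nn2)c(C)c1` is not yet measured; it differs from compound 2 by cyanomethyl in place of 3-chlorophenyl on a saturated chain carbon bound to an aromatic nitrogen. Going by the values given here, the only measured step at this place, a 1.1-fold higher number from compound 1 to compound 2 (0.05 log units; within the scatter), changed nothing beyond the scatter, so for compound 3 no shift beyond the scatter is expected in this assay. Compound 3 is therefore estimated at 190000 nM, between 90000 nM and 400000 nM. This estimate means an expected step of a 1.0-fold higher number from compound 2 to compound 3 (0.01 log units; within the scatter).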

Compound 3, half-maximal cytotoxic concentration: 40200 nM
Estimate against measurement, compound 3: 4.7-fold (0.67 log units) above; the measured number lies below the stated range.
By their numbers in this assay, from the lowest: compound 3; then compounds 1 and 2 (each within the scatter of the next).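

In this assay this position on a saturated chain carbon bound to an aromatic nitrogen does respond to the group placed there. Cyanomethyl in place of 3-chlorophenyl gives a 4.7-fold lower number from compound 2 to compound 3 (0.67 log units; beyond the scatter) and cyanomethyl in place of 4-methylphenyl gives a 4.1-fold lower number from compound 1 to compound 3 (0.61 log units; beyond the scatter) so both ring-bearing compounds stand apart from the ring-free one. Nothing measured here gives a reason for this shift.

This change removes the aromatic ring and adds a nitrile in one move, and the compounds shown cannot separate those two parts. Going by these compounds, how a plain propyl chain or an amine would fare at this place stays open.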